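Nitro for Hydroxy on the Benzyl Ring: Cytotoxicity

The source may report more compounds than this note shows. Statements on the series, on what has been measured and on what is new or still open speak of the compounds shown alone.

Compound 1 `O=c1cc(CNCc2ccccc2O)oc2ccc(O)c(O)c12` gives > 100000 nM
Compound 2 `O=c1cc(CNCc2ccccc2[N+](=O)[O-])oc2ccc(O)c(O)c12` gives 41300 nM
Compound 3 `O=c1cc(CNCc2ccc(O)cc2)oc2ccc(O)c(O)c12` gives 62700 nM

All three were tested in an ADME assay on Huh-7 cells (Homo sapiens) for cytotoxicity; on this read-out lower numbers stand for higher toxicity in this test and higher numbers for lower toxicity in this test. The value of compound 1 is a limit of the test and not a number (the limit of > 100000 nM in this assay, at which 1 of the 3 values shown sits). Compound 2 differs from compound 1 by nitro in place of hydroxy on an aromatic carbon, and the step is an at least 2.4-fold lower number from compound 1 to compound 2 (0.38 log units; beyond the scatter). Compound 3 differs from compound 1 by 4-hydroxyphenyl in place of 2-hydroxyphenyl on a saturated chain carbon bound to an amine nitrogen, with a step of an at least 1.5-fold lower number from compound 1 to compound 3 (0.20 log units; that floor lies within the scatter). Compound 2 and compound 3 lie within the usual scatter of each other.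

Compound 4 `O=c1cc(CNCc2ccc([N+](=O)[O-])cc2)oc2ccc(O)c(O)c12` has not yet been measured. It differs from compound 3 by nitro in place of hydroxy on an aromatic carbon. This is the same kind of change as from compound 1 to compound 2, though not the same: there the nitro stands ortho to a large group, here para to a large group. The step for compound 4 is expected to be a 2.2-fold lower number from compound 3 to compound 4 (0.35 log units; beyond the scatter), which rests on the measured step of an at least 2.4-fold lower number from compound 1 to compound 2 (0.38 log units; beyond the scatter), with extra uncertainty from the changed place. Compound 4 is therefore estimated at 28000 nM, in a range from 12000 nM to 70000 nM.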

Compound 4, half-maximal cytotoxic concentration: 73300 nM
The estimate for compound 4 lay 2.6-fold (0.42 log units) below the measured number; measured number outside the range, above it.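

In this assay, nitro in place of hydroxy, para to a large group, gives a 1.2-fold higher number from compound 3 to compound 4 (0.07 log units; within the scatter), so this change does not carry the same size of step from one pair of compounds to the other: the same change on two cores in this assay, an at least 2.4-fold lower number (0.38 log units; beyond the scatter) from compound 1 to compound 2 and a 1.2-fold higher number (0.07 log units; within the scatter) from compound 3 to compound 4, at least 2.8-fold (0.45 log units) apart, beyond the scatter of two such steps

Compound 1 carries a limit of the test and not a number: the limit of > 100000 nM in this assay, at which 1 of the 4 values shown sits.

As far as these compounds go, the true size of the earlier step therefore stays unknown, and two pairs cannot show why the steps differ, or how the same change would behave on a different core.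

The compounds shown leave open how an amine, a carboxylic acid or a chlorine atom would read in this assay if placed where the nitro stands in compound 4. From the compounds shown here alone, a longer chain on the amine nitrogen is also open, so it remains unclear whether the hydroxy and nitro groups set the numbers in this test or whether other parts of the molecule matter more.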